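Methoxy in Place of Methyl: Expected Tolerance in Liver Cells

The source may hold more compounds than are shown below. What is called first, only, known or untested is meant among the compounds shown, and "the series" means these compounds.

Going by the values given here, compound 2 `Cc1ccccc1COc1c(-c2ccccc2)oc2cc(O)cc(O)c2c1=O` is the only compound with a number rather than a limit: in an ADME assay on Huh-5-2 cells (Homo sapiens) for cytotoxicity, read by WST assay, with a stated time of 3 days (a higher number here means that more compound is tolerated, a lower number that less compound is tolerated), compound 2 gives 55000 nM. Compound 1 `N#Cc1ccccc1COc1c(-c2ccccc2)oc2cc(O)cc(O)c2c1=O` reaches only a limit of this assay, giving > 100000 nM in this assay. Among the compounds with values here, the single measured step, an at least 1.8-fold lower number from compound 1 to compound 2 (0.25 log units; that floor lies within the scatter), thus has a floor set by the limit of > 100000 nM in this assay, at which 1 of the 2 values shown sits, and cannot be placed more precisely. Compound 3 `COc1ccccc1COc1c(-c2ccccc2)oc2cc(O)cc(O)c2c1=O` carries the change (methoxy in place of methyl on an aromatic carbon). No measured step involves a methoxy group, and the only step at that position, cyano to methyl, stays within the scatter at its floor, so the shown data give no direction for the new substituent. For compound 3 the expected step is therefore a 1.1-fold higher number from compound 2 to compound 3 (0.04 log units; within the scatter), no change beyond the scatter. Compound 3 is estimated at 60000 nM in this assay, with a range from 25000 nM to 150000 nM.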

Compound 3, half-maximal cytotoxic concentration: 53000 nM
For compound 3 the middle estimate is 1.1-fold (0.05 log units) above the measured one; the range from low to high includes it.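

Replacing methyl with methoxy on this aromatic carbon, ortho to a large group, gives a 1.0-fold lower number from compound 2 to compound 3 (0.02 log units; within the scatter) in this assay and so provides a second number at this position, one that cannot be told apart from the first. Compound 1 gives > 100000 nM in this assay and this is a limit of the assay, not a number. The comparison of methoxy with cyano therefore reaches only an at least 1.8-fold lower number from compound 1 to compound 3 (0.27 log units; that floor lies within the scatter) and remains a floor, because it rests on that limit: the limit of > 100000 nM in this assay, at which 1 of the 3 values shown sits.

The compounds shown leave open how this position responds to a group of another kind, such as an amine, a carboxylic acid or a longer chain. They also leave open how far the cyano compound, compound 1, lies from the other two.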